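The source may report more compounds than this note shows. Statements on the series, on what has been measured and on what is new or still open speak of the compounds shown alone.

Measured so far in a functional assay on K562 cells (Homo sapiens) for antiproliferative activity, read by MTT assay, with a stated time of 48 h; on this read-out lower numbers stand for stronger inhibition and higher numbers for weaker inhibition:
compound 1 `CN(C)CCCn1c(N)c(-c2nc3ccccc3n2C)c2nc(C#N)c(C#N)nc21` gives 3560 nM
compound 2 `CCN(CC)CCCn1c(N)c(-c2nc3ccccc3n2C)c2nc(C#N)c(C#N)nc21` gives 3270 nM
compound 3 `CN(C)CCCCn1c(N)c(-c2nc3cc(Cl)ccc3[nH]2)c2nc(C#N)c(C#N)nc21` gives 1930 nM

The step from compound 1 to compound 2 is diethylamino in place of dimethylamino on a saturated chain carbon, three bonds along the chain from an aromatic nitrogen; in this assay it reads a 1.1-fold lower number from compound 1 to compound 2 (0.04 log units; within the scatter). Compound 3 carries a different core; the difference between the core of compound 1 and the core of compound 3 is not broken down here, and the two values simply sit close to one another.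

Compound 4 `CCN(CC)CCCCn1c(N)c(-c2nc3cc(Cl)ccc3[nH]2)c2nc(C#N)c(C#N)nc21` is not yet measured. It differs from compound 3 by diethylamino in place of dimethylamino on a saturated chain carbon, four bonds along the chain from an aromatic nitrogen. This is the same kind of change as that from compound 1 to compound 2, but the place is not identical: there the change sits three bonds along the chain from an aromatic nitrogen, here four bonds along the chain. Given that the earlier step was a 1.1-fold lower number from compound 1 to compound 2 (0.04 log units; within the scatter), a step of about the same small size is expected from compound 3 to compound 4, a 1.1-fold lower number from compound 3 to compound 4 (0.03 log units; within the scatter). In this assay compound 4 is estimated at 1800 nM, with a likely range from 900 nM to 3600 nM.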

Compound 4, half-maximal inhibitory concentration: 1270 nM
Estimate against measurement, compound 4: 1.4-fold (0.15 log units) above; measured number inside the range.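

In this assay, diethylamino in place of dimethylamino gives a 1.5-fold lower number from compound 3 to compound 4 (0.18 log units; within the scatter), and set beside the earlier step, the change reads alike on the two cores: the same change on two cores in this assay, a 1.1-fold lower number (0.04 log units; within the scatter) from compound 1 to compound 2 and a 1.5-fold lower number (0.18 log units; within the scatter) from compound 3 to compound 4, 1.4-fold (0.14 log units) apart, within the scatter of two such steps. On these two cores, the change therefore carries over with no difference beyond the scatter, whether it sits three or four bonds along the chain from an aromatic nitrogen. It does not show that the change has any real effect in this assay, as both steps lie within the scatter, and two pairs say nothing about further cores.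

Still open, from the compounds shown here alone, is how a larger amine, such as piperidine or morpholine, would read in place of diethylamino. Going by these compounds, a longer chain on either core also remains untested in these compounds.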